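The source may report more compounds than this note shows. Statements on the series, on what has been measured and on what is new or still open speak of the compounds shown alone.

Measured so far:
compound 1 `CCCCCCCCCCCCS(=O)(=O)CC(O)(O)C(F)(F)F` with 741 nM
compound 2 `CCCCCCCC[S+]([O-])CC(O)(O)C(F)(F)F` with 14800 nM

In an assay on isolated protein for inhibition of liver carboxylesterase 1 (Homo sapiens), with a stated time of 5 min (on this read-out higher numbers stand for weaker inhibition and lower numbers for stronger inhibition), compound 1 gives the lowest of the two numbers; compound 2 gives a number that is far higher, beyond the scatter. Compound 3 `CCCCCCS(=O)(=O)CC(O)(O)C(F)(F)F` differs from compound 1 by hydrogen in place of hexyl on a saturated chain carbon, six bonds along the chain from a sulfonyl sulfur. For the measured compounds named here, no step between measured compounds isolates this change; compound 2 differs from compound 1 in more than one place. Weaker inhibition is expected for compound 3, with a step of a 5.4-fold higher number from compound 1 to compound 3 (0.73 log units; beyond the scatter) beyond the scatter. Compound 3 is therefore estimated at 4000 nM, in the range 1200 nM to 15000 nM.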

Compound 3, inhibition constant: 9770 nM
For compound 3 the middle estimate is 2.4-fold (0.39 log units) below the measured one; the measured number falls inside the stated range.
By their numbers in this assay, from the lowest: compound 1; then compounds 3 and 2 (each within the scatter of the next).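

In this assay, for the compounds shown here, putting hydrogen in place of hexyl on a saturated chain carbon, six bonds along the chain from a sulfonyl sulfur, gives a 13-fold higher number from compound 1 to compound 3 (1.12 log units; beyond the scatter) as the only step that isolates this position. The outer hexyl portion of compound 1 therefore matters for inhibition: removing it clearly weakens the read-out. The compounds shown leave open whether a longer chain would strengthen inhibition further, and whether a phenyl ring or an ether at this place could stand in for hexyl. Nothing measured here accounts for the loss.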